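This account rests on a few compounds, and the source may have more. Where it says the series, first, only, none or still open, it means among the compounds named here.

Of the compounds shown here, two of this small set have already been tested in a functional assay on MDA-MB-231 cells (Homo sapiens) for inhibition, read by MTT assay, with a stated time of 24 h; a higher number here means a weaker inhibitor, a lower number a stronger inhibitor. Compound 1 `[O-]/[N+](=C\c1cn(-c2ccc(C(F)(F)F)cc2)nn1)Cc1ccccc1` is reported only as a limit of the measurement, > 100000 nM, so no number is known for it. Compound 2 `COc1ccc(-n2cc(/C=[N+](\[O-])C(C)(C)C)nn2)cc1` gives 23100 nM in this assay, the only real number among the two results shown. The next compound, compound 3 `CC(C)(C)/[N+]([O-])=C/c1cn(-c2ccc(C(F)(F)F)cc2)nn1`, is not yet measured; it differs from compound 2 in a single place: trifluoromethyl in place of methoxy on an aromatic carbon. Among the compounds with values here, no pair of measured compounds differs by this change alone, so there is no measured step to draw on. Compound 1, which also carries trifluoromethyl, sits at the limit of > 100000 nM in this assay, at which 1 of the 2 values shown sits. The step from compound 2 to compound 3 is expected to be modest and toward weaker inhibition, a 1.7-fold higher number from compound 2 to compound 3 (0.24 log units; within the scatter). Compound 3 is estimated at 40000 nM in this assay, within a range from 12000 nM to 150000 nM.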

Compound 3, half-maximal inhibitory concentration: 48200 nM
Compound 3: the middle estimate sits 1.2-fold (0.08 log units) below what was measured; measured number inside the range.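

Trifluoromethyl in place of methoxy, para to a large group, gives a 2.1-fold higher number from compound 2 to compound 3 (0.32 log units; beyond the scatter) in this assay, so this change now has a measured size and direction, toward weaker inhibition. With trifluoromethyl held fixed, tert-butyl in place of benzyl on a double-bonded nitrogen gives an at least 2.0-fold lower number from compound 1 to compound 3 (0.31 log units; beyond the scatter), which points toward stronger inhibition. Compound 1 is a limit of the assay and not a number, so the full size of this second step stays unknown: the limit of > 100000 nM in this assay, at which 1 of the 3 values shown sits.

The compounds shown leave open how an amine or a carboxylic acid on that aromatic carbon would read, since only methoxy and trifluoromethyl appear there. They also leave open whether the step from benzyl to tert-butyl would keep its direction with methoxy on the aromatic ring.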